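The source may hold more compounds than are shown below. What is called first, only, known or untested is meant among the compounds shown, and "the series" means these compounds.

Compound 1 `NS(=O)(=O)CC(=O)NCCSc1nonc1/C(=N/O)Nc1cccc(C(F)F)c1`, 130 nM. Compound 2 `CC1(C(=O)NCCSc2nonc2/C(=N/O)Nc2ccc(F)c(C(F)F)c2)CCN1`, 360 nM. Compound 3 `CS(=N)(=O)CC(=O)NCCSc1nonc1/C(=N/O)Nc1ccc(F)c(Br)c1`, 61 nM.

Of the compounds shown here, three sharing one core have been tested in an assay for inhibition of Indoleamine 2,3-dioxygenase 1 (Homo sapiens), read by fluorescence, with a stated time of 1 h; on this read-out lower numbers stand for stronger inhibition and higher numbers for weaker inhibition. Compound 1 stands second highest of the three numbers: compound 3 gives a lower number and compound 2 a higher one, and both gaps lie beyond the usual scatter of repeated measurements. Compound 4 `N#Cc1cc(N/C(=N\O)c2nonc2SCCNC(=O)CS(N)(=O)=O)ccc1F` has not yet been measured. It differs from compound 1 in one place: 3-cyano-4-fluorophenyl in place of 3-(difluoromethyl)phenyl on an amine nitrogen. Among the compounds with values here, none of the measured compounds differ from one another in only a single place, so no measured step shows what a change of this kind alone does; the three measured compounds vary at several positions at once. Given that, the expectation is a modest step from compound 1 to compound 4, roughly a 1.2-fold higher number from compound 1 to compound 4 (0.06 log units; within the scatter), with no clear direction beyond the scatter. Compound 4 is therefore estimated at about 150 nM in this assay, within a range of 55 nM to 420 nM.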

Compound 4, half-maximal inhibitory concentration: 150 nM
The estimate for compound 4 equals the measured number at the digits printed; the range from low to high includes it.
By their numbers in this assay, from the lowest: compound 3; then compounds 1 and 4 (each within the scatter of the next); then compound 2.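

In this assay, within the data shown here, the change of 3-(difluoromethyl)phenyl to 3-cyano-4-fluorophenyl on an amine nitrogen gives a 1.2-fold higher number from compound 1 to compound 4 (0.06 log units; within the scatter), the first comparison here in which only one place differs. At this position, then, a ring carrying a nitrile and a fluorine cannot be told apart from one carrying a difluoromethyl group, even though the entering group brings a triple bond and a hydrogen-bond acceptor that the leaving group lacks. Nothing in the data explains why these two compounds read alike. The nitrile and the fluorine enter together. The compounds shown leave open what each does alone, which a phenyl ring carrying only one of them would test. They also leave open whether this position accepts a carboxylic acid or an amine on the ring.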